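The source may hold more compounds than are shown below. What is called first, only, known or untested is meant among the compounds shown, and "the series" means these compounds.

The measured compounds, with their numbers in a functional assay on CCRF-CEM cells (Homo sapiens) for antiproliferative activity, read by MTT assay, with a stated time of 3 days; a lower number here means a stronger inhibitor, a higher number a weaker inhibitor:

Compound 1, `CCCCCCC#Cc1cn(C/C=C/CN2C(=O)c3ccccc3C2=O)c(=O)[nH]c1=O`: compound 1 gives 28000 nM.
Compound 2, `O=C1c2ccccc2C(=O)N1C/C=C\Cn1cc(C#Cc2ccc(Br)cc2)c(=O)[nH]c1=O`: compound 2 gives 80000 nM.
Compound 3, `CCCCc1ccc(C#Cc2cn(C/C=C\CN3C(=O)c4ccccc4C3=O)c(=O)[nH]c2=O)cc1`: compound 3 gives 23000 nM.

Compound 1 stands second highest of the three numbers. Its nearest neighbour is compound 3, whose number is within the scatter of that of compound 1, so no order between the two can be claimed; compound 2 stands furthest, with a number beyond the scatter above that of compound 1.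

The unmeasured compound 4, `CCCCCc1ccc(C#Cc2cn(C/C=C/CN3C(=O)c4ccccc4C3=O)c(=O)[nH]c2=O)cc1`, arises from compound 1 by 4-pentylphenyl in place of hexyl on a triple-bonded carbon.

Within the data shown here, only one single-point step is known, a 3.5-fold lower number from compound 2 to compound 3 (0.54 log units; beyond the scatter), and it concerns the substituent on the aryl ring rather than the exchange of a chain for an aryl group, so it bears on the present step only indirectly. Compound 1 and compound 3 differ in more than one place, so only their two numbers speak: they lie within the scatter of each other, which suggests that a chain and an alkyl-bearing aryl group on the triple-bonded carbon give much the same number. Compound 4 is therefore expected to show a 1.3-fold lower number from compound 1 to compound 4 (0.10 log units; within the scatter), a change within the scatter. The estimate for compound 4 in this assay is 22000 nM, with a range from 9000 nM to 55000 nM.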

Compound 4, half-maximal inhibitory concentration: 23000 nM
Beside the measured number, compound 4's estimate is 1.0-fold (0.02 log units) below it; measured number inside the range.
By their numbers in this assay, from the lowest: compounds 3, 4 and 1 (each within the scatter of the next); then compound 2.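

In this assay, the exchange on the triple-bonded carbon can now be read directly: a 1.2-fold lower number from compound 1 to compound 4 (0.09 log units; within the scatter). Hexyl, with no ring, and 4-pentylphenyl, with one six-membered aromatic ring of carbon only, therefore give numbers that cannot be told apart on this core, although the entering group is the larger by heavy atoms; before, the comparison of a chain with an aryl group rested only on compounds that differ in more than one place. Nothing measured here offers an explanation for this result.

Still open, as far as these compounds go, is whether an amine or a carboxylic acid at the end of the pentyl chain would shift the number at this position. Also open, from the compounds shown here alone, is whether a chain longer than hexyl would leave it within the scatter.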